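The source may report more compounds than this note shows. Statements on the series, on what has been measured and on what is new or still open speak of the compounds shown alone.

Of the compounds shown here, three from this series have been tested in a functional assay on A549 cells (Homo sapiens) for antiproliferative activity, read by sulforhodamine B assay, with a stated time of 48 h; a higher number here means a weaker inhibitor, a lower number a stronger inhibitor. Compound 1 `COc1ccc2nc(-c3ccc(N/C=C\C(=O)c4cc(OC)c(OC)c(OC)c4)c(C)c3)sc2c1` gives 11100 nM in this assay. Compound 3 `COc1cc(OC)c2sc(-c3ccc(N/C=C\C(=O)c4cc(OC)c(OC)c(OC)c4)c(C)c3)nc2c1` gives 14400 nM in this assay. Compound 2 `COc1cc(OC)c2sc(-c3ccc(N/C=C\C(=O)c4cc(OC)c(OC)c(OC)c4Br)c(C)c3)nc2c1` gives 14000 nM in this assay. The three values lie within the usual scatter of one another, so no ordering among them can be read from the data.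

Compounds 2 and 3 share a core and differ in one place: bromo in place of hydrogen on an aromatic carbon. The step they show in this assay is a 1.0-fold lower number from compound 3 to compound 2 (0.01 log units; within the scatter), meaning the added bromo left the result essentially unchanged on that core.

Compound 4 `COc1ccc2nc(-c3ccc(N/C=C\C(=O)c4cc(OC)c(OC)c(OC)c4Br)c(C)c3)sc2c1` has not yet been measured. It relates to compound 1 exactly as compound 2 relates to compound 3: bromo in place of hydrogen on an aromatic carbon. The place of the change is described in the same words for both pairs, so this is the same change, carried onto the core of compound 1. The difference between the core of compound 1 and the core of compound 3 is not broken down here.

Among the measured compounds shown here, since the only precedent for this change, the step from compound 3 to compound 2, lies within the scatter, compound 4 is expected to show a step of about a 1.0-fold lower number from compound 1 to compound 4 (0.00 log units; within the scatter) in this assay. On that basis compound 4 is estimated at 11000 nM in this assay, with a plausible range from 5500 nM to 22000 nM.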

Compound 4, half-maximal inhibitory concentration: 6400 nM
Compound 4: middle estimate off by 1.7-fold (0.24 log units), on the high side; the range from low to high includes it.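

On the core of compound 1, bromo in place of hydrogen on an aromatic carbon gives in this assay a 1.7-fold lower number from compound 1 to compound 4 (0.24 log units; within the scatter), so on this core, as on the core of compound 3, the step stays inside the usual scatter of the measurement. Set beside each other, the two steps cannot be told apart, and the change carries from one core to the other without any measurable dependence on the core: the same change on two cores in this assay, a 1.0-fold lower number (0.01 log units; within the scatter) from compound 3 to compound 2 and a 1.7-fold lower number (0.24 log units; within the scatter) from compound 1 to compound 4, 1.7-fold (0.23 log units) apart, within the scatter of two such steps What this does not show is that bromo has a real effect on either core, or that the agreement would extend to any core other than these two, as it rests on only two pairs of compounds, and both steps are small enough to be lost in the scatter.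

The compounds shown leave open whether a different group on that same aromatic carbon, such as chloro, a nitrile, an amine or a carboxylic acid, would give a step beyond the scatter. They also leave open what would follow from replacing one of the methoxy groups on that ring with a hydroxy group or a longer alkoxy chain.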